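A few compounds are considered here, and "the series" means these few. Any claim that something is new, unique, unknown or untested is made for them only; others in the source may bear on it.

Compounds measured in an ADME assay on SW480 cells (Homo sapiens) for cytotoxicity, read by MTT assay, with a stated time of 72 h; on this read-out higher numbers stand for weaker inhibition and lower numbers for stronger inhibition:
- compound 1, `CCOc1ccc(NC(=O)c2cccc(/C=C3\CC(=O)N(Cc4ccccc4)C3=O)c2)cc1`, gives 73200 nM.
- compound 2, `COc1ccc(NC(=O)c2cccc(/C=C3\CC(=O)N(c4ccccc4)C3=O)c2)cc1`, gives only a limit, > 100000 nM, which marks the edge of the assay rather than a number.
- compound 3, `COc1ccc(NC(=O)c2cccc(/C=C3\CC(=O)N(c4ccc(C)cc4)C3=O)c2)cc1`, gives 93000 nM.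

Compound 2 thus stands at the limit of > 100000 nM in this assay, at which 1 of the 3 values shown sits, so only a range is known for it. For the measured compounds named here, the single measured step, an at least 1.0-fold lower number from compound 2 to compound 3 (0.03 log units; that floor lies within the scatter), alters the other phenyl ring and stays within the scatter. Compound 4, `O=C(Nc1cccc(F)c1)c1cccc(/C=C2\CC(=O)N(c3ccccc3)C2=O)c1`, differs from compound 2 by 3-fluorophenyl in place of 4-methoxyphenyl on an amide-type nitrogen. Going by the values given here, no measured step changes this amide-type nitrogen substituent, so nothing among the measured compounds points to a shift beyond the scatter in this assay. Compound 4 is therefore expected to show a number no higher from compound 2 to compound 4 (the limit leaves the size open), close to the limit. The estimate for compound 4 is 100000 nM, ranging from 40000 nM to 250000 nM.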

Compound 4, half-maximal inhibitory concentration: > 100000 nM
Compound 4: no number, only a limit; the forecaster's own chance of this, stated with the estimate: 55%; the middle value sits exactly at the limit.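

In this assay compound 4 gives > 100000 nM, which is a limit and not a number. Compound 2 also stands at a limit, so the step between compound 2 and compound 4 cannot be read. Going by these compounds, whether 3-fluorophenyl in place of 4-methoxyphenyl changes the read-out at all stays open.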